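Reversing the linker and swapping acetyl for nitro

The source may hold more compounds than are shown below. What is called first, only, known or untested is meant among the compounds shown, and "the series" means these compounds.

For the measured compounds named here, compound 1 `CC(=O)c1ccc(CNc2ccc(-c3c(N)nc(N)nc3COCc3ccccc3)cc2)cc1` gives 1.2 nM in an in vitro assay on CHOK cells for displacement of a labelled ligand from growth hormone secretagogue receptor type 1 (Homo sapiens) (on this read-out lower numbers stand for stronger inhibition and higher numbers for weaker inhibition), the lower of the two numbers known, and compound 2 `Nc1nc(N)c(-c2ccc(NCc3ccc(Cl)cc3)cc2)c(CCc2ccccc2)n1` gives 3170 nM in this assay, a gap far beyond the scatter. Compound 3 `Nc1nc(N)c(-c2ccc(CNc3ccc([N+](=O)[O-])cc3)cc2)c(COCc2ccccc2)n1` differs from compound 1 only in ((4-nitrophenyl)amino)methyl in place of (4-acetylbenzyl)amino on an aromatic carbon. Going by the values given here, no step between measured compounds covers this change, so the expectation rests on compound 1 alone, and a loss of some size is expected, with an 8.3-fold higher number from compound 1 to compound 3 (0.92 log units; beyond the scatter). Compound 3 is therefore estimated at 10 nM in this assay, within a range from 1.5 nM to 100 nM.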

Compound 3, half-maximal inhibitory concentration: 0.8 nM
Estimate against measurement, compound 3: 13-fold (1.10 log units) above, and the stated range ends above it.
By their numbers in this assay, from the lowest: compounds 3 and 1 (each within the scatter of the next); then compound 2.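

In this assay, the step is a 1.5-fold lower number from compound 1 to compound 3 (0.18 log units; within the scatter), so at this place, on an aromatic carbon para to a large group, ((4-nitrophenyl)amino)methyl serves as well as (4-acetylbenzyl)amino. Reversing the linker and exchanging acetyl for nitro together leave the number within the scatter, which the earlier compounds could not show. Nothing at hand gives a reason for this result. The compounds shown leave open how the linker reversal and the exchange of acetyl for nitro would each read alone. They also leave open whether a nitrile or a carboxylic acid in place of the nitro group would hold the number.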